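The compounds below may be only part of what the source reports. "The series", "measured", "known", "first", "only" and "open" are said of these compounds alone.

Working notes on the series. Among the measured compounds shown here, in a functional assay on SW-620 cells (Homo sapiens) for inhibition, read by MTT assay, with a stated time of 48 h (on this read-out lower numbers stand for stronger inhibition and higher numbers for weaker inhibition), compound 2 `Cc1ccc(NC(=O)NC(=O)c2ccc(OCc3cccc(Cl)c3)cc2)cc1-c1nc2ccccc2[nH]1` gives 16000 nM, the only number so far in this set, so compound 2 stands as the single compound with a measured value. Compound 1 `Cc1ccc(NC(=S)NC(=O)c2ccc(OCc3cccc(Cl)c3)cc2)cc1-c1nc2ccccc2[nH]1` returns a limit rather than a number in this assay, > 100000 nM. That result is recorded as the limit of > 100000 nM in this assay, at which 1 of the 2 values shown sits. Between compound 1 and compound 2 only the two results themselves are available, and no step is drawn between them.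

Compound 3 `Cc1ccc(NC(=O)NC(=O)c2ccc(OCc3ccccc3Cl)cc2)cc1-c1nc2ccccc2[nH]1` is not yet measured in this assay. It differs from compound 2 by 2-chlorophenyl in place of 3-chlorophenyl on a saturated chain carbon bound to an oxygen on an aromatic ring. For the measured compounds named here, no measured step in this set covers a move of the chlorine around the benzyl ring, so the expectation rests on the value of compound 2 16000 nM alone. A change of this kind is expected to shift this assay by little or nothing beyond the scatter, and the estimated step of no change at the digits printed from compound 2 to compound 3 (within the scatter) is set accordingly. Compound 3 is therefore expected to give around 16000 nM in this assay, with a range from 6000 nM to 45000 nM.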

Compound 3, half-maximal inhibitory concentration: 35700 nM
Compound 3: middle estimate off by 2.2-fold (0.35 log units), on the low side, and the stated range covers the measured number.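

Among the compounds shown here, the move of the chlorine around the benzyl ring is the first change that can be read as a step: in this assay, 2-chlorophenyl in place of 3-chlorophenyl gives a 2.2-fold higher number from compound 2 to compound 3 (0.35 log units; beyond the scatter). The atoms are the same on both sides, so at this place, on a saturated chain carbon bound to an oxygen on an aromatic ring, the position of the chlorine alone is enough to give weaker inhibition, though the step is modest. Nothing recorded for the series accounts for this step.

Going by these compounds, whether the chlorine is needed at all remains open, as does the outcome with 4-chlorophenyl, an unsubstituted phenyl, or a methoxy group or fluorine in its place, so two positions of one halogen are all that can be said about this ring. Compound 1 gives only a limit, > 100000 nM, and not a number, so its step to the other compounds cannot be read.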